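Naphthalen-2-yl to naphthalen-1-yl: working notes on the series

The source may report more compounds than this note shows. Statements on the series, on what has been measured and on what is new or still open speak of the compounds shown alone.

In a functional assay on MCF7 cells (Homo sapiens) for antiproliferative activity, read by MTT assay, with stated times of 24 h and 72 h (on this read-out lower numbers stand for stronger inhibition and higher numbers for weaker inhibition), compound 1 (`COc1cccc([C@@H]2[C@H](Oc3ccccc3)C(=O)N2c2cc(OC)c(OC)c(OC)c2)c1`) gives 171000 nM and compound 2 (`COc1cc(N2C(=O)[C@@H](Oc3ccccc3)[C@H]2c2ccc3ccccc3c2)cc(OC)c1OC`) gives 282000 nM on the same read-out. Within the data shown here, these are the only two numbers so far, and compound 2 stands level with compound 1 within the scatter. The next structure is compound 3 (`COc1cc(N2C(=O)[C@@H](Oc3ccccc3)[C@H]2c2cccc3ccccc23)cc(OC)c1OC`), in which naphthalen-1-yl replaces naphthalen-2-yl on a saturated ring carbon (naphthalen-1-yl in place of naphthalen-2-yl on a saturated ring carbon). Among the measured compounds shown here, one measured step bears on this change: a 1.6-fold higher number from compound 1 to compound 2 (0.22 log units; within the scatter) for naphthalen-2-yl in place of 3-methoxyphenyl, a step within the scatter. For the measured compounds named here, no measured compound carries naphthalen-1-yl, and the data give no direction. The expected shift is none beyond the scatter (a 1.2-fold lower number from compound 2 to compound 3 (0.09 log units; within the scatter)). In this assay compound 3 is estimated at 230000 nM (expected range 90000 nM to 550000 nM).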

Compound 3, half-maximal inhibitory concentration: 53000 nM
The estimate for compound 3 lay 4.3-fold (0.64 log units) above the measured number, outside the stated range (below it).
By their numbers in this assay, from the lowest: compound 3; then compounds 1 and 2 (each within the scatter of the next).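

In this assay, naphthalen-1-yl in place of naphthalen-2-yl, with the same atoms joined differently on the saturated ring carbon next to the ring nitrogen, gives a 5.3-fold lower number from compound 2 to compound 3 (0.73 log units; beyond the scatter), so the point of attachment of this group counts at this position, which the earlier step within the scatter could not show. Naphthalen-1-yl in place of 3-methoxyphenyl also gives a step beyond the scatter, a 3.2-fold lower number from compound 1 to compound 3 (0.51 log units; beyond the scatter), whereas naphthalen-2-yl in place of 3-methoxyphenyl did not, with a 1.6-fold higher number from compound 1 to compound 2 (0.22 log units; within the scatter). Nothing available accounts for the difference between the two attachment points.

This reading rests on a single pair of isomers, and the steps remain modest. Open, from the compounds shown here alone, is whether the step survives an amine or a carboxylic acid on naphthalen-1-yl, or a hydroxyl in place of the phenoxy group.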